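Cytotoxicity after swapping a pyridyl ether for a trifluoromethylphenyl ether

The compounds below may be only part of what the source reports. "The series", "measured", "known", "first", "only" and "open" are said of these compounds alone.

Measured so far:
- compound 1, `CC(CCNC(=O)c1c(Cl)cncc1Cl)N1CCC(C(Oc2cccc(C(F)(F)F)c2)c2ccc(C(F)(F)F)cc2)CC1`: 7000 nM
- compound 2, `CC(CCNC(=O)c1c(Cl)cncc1Cl)N1CCC(C(Oc2ncccc2Cl)c2ccc(C(F)(F)F)cc2)CC1`: 16700 nM
- compound 3, `Cc1cccc(OC(c2ccc(C(F)(F)F)cc2)C2CCN(C(C)CCNC(=O)c3c(Cl)cncc3Cl)CC2)n1`: 6700 nM

In an ADME assay on PBMC cells (Homo sapiens) for cytotoxicity (on this read-out higher numbers stand for lower toxicity in this test and lower numbers for higher toxicity in this test), compound 3 shows the lowest of the three numbers, but its gap to compound 1 lies within the scatter, so only compound 2 is clearly apart from it, by a 2.5-fold lower number from compound 2 to compound 3 (0.40 log units; beyond the scatter).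

Compound 4, `CC(CCNC(=O)c1c(Cl)cncc1Cl)N1CCC(C(Oc2ccc(C(F)(F)F)cc2)c2ccc(C(F)(F)F)cc2)CC1`, is not yet measured. It differs from compound 3 in one place: 4-(trifluoromethyl)phenyl in place of 6-methylpyridin-2-yl on an oxygen on a saturated carbon.

Within the data shown here, two measured steps touch this position. The step of a 1.0-fold lower number from compound 1 to compound 3 (0.02 log units; within the scatter) shows that moving between a trifluoromethylphenyl ether and the 6-methylpyridin-2-yl ether left the number essentially where it was. The step of a 2.4-fold higher number from compound 1 to compound 2 (0.38 log units; beyond the scatter) shows that the 3-chloropyridin-2-yl ether raised it only modestly. Since compound 4 carries a trifluoromethylphenyl group much like compound 1, the step from compound 3 is expected to stay within the scatter, at about a 1.0-fold higher number from compound 3 to compound 4 (0.02 log units; within the scatter).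

For compound 4 the expected value in this assay is 7000 nM, with a range from 3500 nM to 14000 nM.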

Compound 4, half-maximal cytotoxic concentration: 3100 nM
For compound 4 the middle estimate is 2.3-fold (0.35 log units) above the measured one, and the stated range ends above it.
By their numbers in this assay, from the lowest: compound 4; then compounds 3 and 1 (each within the scatter of the next); then compound 2.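

In this assay, the place of the trifluoromethyl group on the phenyl ether now matters: 4-(trifluoromethyl)phenyl in place of 3-(trifluoromethyl)phenyl gives a 2.3-fold lower number from compound 1 to compound 4 (0.35 log units; beyond the scatter), although both groups contain the same atoms. The same change from the two pyridyl ethers gives a 2.2-fold lower number from compound 3 to compound 4 (0.33 log units; beyond the scatter) and a 5.4-fold lower number from compound 2 to compound 4 (0.73 log units; beyond the scatter), so the range at this oxygen is wider than the first three compounds showed, with 4-(trifluoromethyl)phenyl at its low end. Nothing available here explains these differences.

The compounds shown leave open whether this drop is specific to trifluoromethyl or would also appear with another group in its place, such as a 4-chlorophenyl or 4-methoxyphenyl ether. They also leave open how an amine or a carboxylic acid on this ring would read.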